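Trifluoromethoxy for methoxy on the benzamide of compound 2

The compounds below may be only part of what the source reports. "The series", "measured", "known", "first", "only" and "open" are said of these compounds alone.

Among the compounds with values here, compound 2 `COc1ccc(C(=O)Nc2cc(-c3ccccc3)nn2-c2ccccc2)cc1` gives 54 nM in a functional assay on cells for positive allosteric modulation of metabotropic glutamate receptor 5 (Rattus norvegicus), read by calcium flux (a lower number here means that less compound is needed, a higher number that more compound is needed for the effect), the lower of the two numbers measured so far; compound 1 `O=C(Nc1cc(-c2ccccc2)nn1-c1ccccc1)c1ccccc1` gives 203 nM in this assay. Within the data shown here, the only measured step, a 3.8-fold lower number from compound 1 to compound 2 (0.58 log units; beyond the scatter), shows that a group at this place is tolerated and helps. Compound 3 `O=C(Nc1cc(-c2ccccc2)nn1-c1ccccc1)c1ccc(OC(F)(F)F)cc1` carries trifluoromethyl in place of methyl on an oxygen on an aromatic ring. Among the measured compounds shown here, no measured step covers an exchange of this kind, so no direction is expected beyond the scatter; the estimated step is a 1.1-fold higher number from compound 2 to compound 3 (0.05 log units; within the scatter). Compound 3 is therefore expected to give 60 nM in this assay, with a range from 20 nM to 200 nM.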

Compound 3, half-maximal effective concentration: 18 nM
Compound 3: the middle estimate sits 3.3-fold (0.52 log units) above what was measured; the measured number lies below the stated range.
By their numbers in this assay, from the lowest: compound 3; then compound 2; then compound 1.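

In this assay, the identity of the group on this oxygen matters: trifluoromethyl in place of methyl gives a 3.0-fold lower number from compound 2 to compound 3 (0.48 log units; beyond the scatter) and so extends the gain seen with methoxy. Relative to hydrogen on the aromatic carbon, trifluoromethoxy gives an 11-fold lower number from compound 1 to compound 3 (1.05 log units; beyond the scatter) and moves the series from a modest step to a large one. The data at hand offer no explanation for this gain.

Still open, on these data alone, is whether a longer chain such as ethoxy, or an amine or a nitrile, at this place keeps the gain. Also open, as far as these compounds go, is whether trifluoromethoxy helps elsewhere on the shared core.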